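The source may hold more compounds than are shown below. What is called first, only, known or untested is meant among the compounds shown, and "the series" means these compounds.

Measured so far in a functional assay on A-431 cells (Homo sapiens) for cytotoxicity, read by MTT assay, with a stated time of 24 h; a lower number here means a stronger inhibitor, a higher number a weaker inhibitor:

Compound 1 `COc1cccc(-n2cc(COc3c(/C=C\C(=O)O)ccc(OC)c3CC=C(C)C)nn2)c1` gives 23200 nM.
Compound 2 `COc1ccc(/C=C\C(=O)O)c(OCc2cn(-c3ccc(CO)cc3)nn2)c1CC=C(C)C` gives 16400 nM.

Both compounds share one core and differ only in the group carried on an aromatic nitrogen. The step from one to the other, a 1.4-fold lower number from compound 1 to compound 2 (0.15 log units; within the scatter), lies within the scatter of repeated measurements, so compound 2 cannot be told apart from compound 1 on these numbers, and neither compound counts as the stronger inhibitor.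

Compound 3 `COc1ccc(/C=C\C(=O)O)c(OCc2cn(-c3nc4ccccc4s3)nn2)c1CC=C(C)C` carries a further variation at the same place: 1,3-benzothiazol-2-yl in place of 4-(hydroxymethyl)phenyl on an aromatic nitrogen. Among the compounds with values here, the only measured step that bears on this position is the one from compound 1 to compound 2, and it produced no change beyond the scatter. On that basis the expectation for compound 3 is a step of about a 1.1-fold lower number from compound 2 to compound 3 (0.04 log units; within the scatter) in this assay, that is, no change that could be distinguished from noise. Compound 3 is therefore estimated at 15000 nM, with a range of 5000 nM to 45000 nM.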

Compound 3, half-maximal inhibitory concentration: 20800 nM
Compound 3: the middle estimate sits 1.4-fold (0.14 log units) below what was measured, within the range that was stated.
By their numbers in this assay, from the lowest: compounds 2, 3 and 1 (each within the scatter of the next).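

In this assay, 1,3-benzothiazol-2-yl in place of 4-(hydroxymethyl)phenyl gives a 1.3-fold higher number from compound 2 to compound 3 (0.10 log units; within the scatter) and 1,3-benzothiazol-2-yl in place of 3-methoxyphenyl gives a 1.1-fold lower number from compound 1 to compound 3 (0.05 log units; within the scatter) so neither step can be told apart from noise. The earlier pair compared only groups with one six-membered aromatic ring of carbon only, whereas compound 3 adds a five-membered aromatic ring holding 2 hetero atoms and has no hydrogen-bond donor in this group, yet its number still cannot be separated from those of compound 1 and compound 2. No measured evidence here explains this result.

All three groups on this nitrogen are aromatic, so the compounds shown leave open what a plain butyl chain, or a ring carrying an amine or a carboxylic acid, would do. Going by these compounds, whether any group at this position can move the number beyond the scatter also remains open.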